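This account rests on a few compounds, and the source may have more. Where it says the series, first, only, none or still open, it means among the compounds named here.

Compound 1 `CC(C)(C)c1cc(C(=O)Nc2nc(CN)cs2)n(-c2ccccc2)n1` gives 160 ug/mL in a physicochemical assay for solubility, read by turbidimetry, measured as kinetic solubility, at pH 7.4; a higher number here means a more soluble compound, a lower number a less soluble compound. Compound 2 `NCc1csc(NC(=O)c2cccs2)n1` gives 80 ug/mL in this assay. Compound 3 `NCc1csc(NC(=O)c2cnccn2)n1` is reported at > 200 ug/mL in this assay, which is a limit of the assay rather than a number (the limit of > 200 ug/mL in this assay, at which 1 of the 3 values shown sits).

Compound 1 stands together with compound 2 inside the usual scatter of repeated measurements, so the two numbers cannot be told apart. Compound 4 `CC(C)(C)c1cc(C(=O)Nc2nc(CN)cs2)n(Cc2ccc(Br)cc2)n1` differs from compound 1 in one place: 4-bromobenzyl in place of phenyl on an aromatic nitrogen. No measured pair of compounds differing in a single spot exists here, so the size of this step cannot be read from the numbers shown. A moderate fall in this assay, beyond the scatter, is expected, the estimated step being a 4.0-fold lower number from compound 1 to compound 4 (0.60 log units; beyond the scatter). Compound 4 is estimated at 40 ug/mL, with a range from 15 ug/mL to 100 ug/mL.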

Compound 4, solubility: > 200 ug/mL
Compound 4: only a limit was reported (the forecaster's own chance of this, stated with the estimate: 5%); at least 5.0-fold (0.69 log units) between middle value and limit.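

In this assay, 4-bromobenzyl in place of phenyl on this aromatic nitrogen gives an at least 1.2-fold higher number from compound 1 to compound 4 (0.09 log units; that floor lies within the scatter). This position therefore takes the bigger group, with its bromine, and no fall appears in the read-out. The value of compound 4 is a limit of the assay, not a number, so the true size of the step cannot be read: the limit of > 200 ug/mL in this assay, at which 2 of the 4 values shown sit.

Left open is what a plain benzyl without the bromine, or a simple methyl, would give on this nitrogen.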